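This account rests on a few compounds, and the source may have more. Where it says the series, first, only, none or still open, it means among the compounds named here.

Compound 1 `COc1ccc(CN(Cc2ccc(C(C)(C)C)cc2)Cc2cc3cc(C)ccc3[nH]c2=O)cc1` and compound 2 `CCc1ccc2[nH]c(=O)c(CN(Cc3ccc(C(C)(C)C)cc3)[C@H](CO)c3ccccc3)cc2c1` share one core. In a toxicity assay on MDCK cells (Canis lupus familiaris) for cytotoxicity, read by crystal violet staining, with a stated time of 48 h (a higher number here means that more compound is tolerated, a lower number that less compound is tolerated), compound 1 gives only the assay limit, > 10000 nM. In this assay compound 2 likewise gives only a limit, > 10000 nM. For the measured compounds named here, both values sit at the same ceiling (the limit of > 10000 nM in this assay, at which 2 of the 2 values shown sit), so no step between measured compounds can be sized. Compound 3 `Cc1ccc2[nH]c(=O)c(CN(Cc3ccc(C(C)(C)C)cc3)C(C)c3ccc(N(C)C)c(Cl)c3)cc2c1` differs from compound 1 by 1-(3-chloro-4-(dimethylamino)phenyl)ethyl in place of 4-methoxybenzyl on an amine nitrogen. With both known values at the limit, the expected step from compound 1 to compound 3 is an at least 1.1-fold lower number from compound 1 to compound 3 (0.04 log units; that floor lies within the scatter), none beyond the scatter, though a number just under the limit would not surprise. For compound 3 the estimate in this assay is 9000 nM, within 3000 nM to 25000 nM.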

Compound 3, half-maximal cytotoxic concentration: 9800 nM
The estimate for compound 3 lay 1.1-fold (0.04 log units) below the measured number; measured number inside the range.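

In this assay compound 3 gives the series its first number that is not a limit, 9800 nM, so tolerance on this amine nitrogen now has a reading. Placing 1-(3-chloro-4-(dimethylamino)phenyl)ethyl there in place of 4-methoxybenzyl gives an at least 1.0-fold lower number from compound 1 to compound 3 (0.00 log units; that floor lies within the scatter). This step is only a floor, and its true size cannot be read: the limit of > 10000 nM in this assay, at which 2 of the 3 values shown sit.

Open: which part of the entering group, the chlorine, the dimethylamino or the branching methyl, goes with the number in compound 3. Also open, going by these compounds, is how a benzyl carrying a carboxylic acid would read on this nitrogen.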